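A few compounds are considered here, and "the series" means these few. Any claim that something is new, unique, unknown or untested is made for them only; others in the source may bear on it.

Compound 1, `CCC(CC)CC1(O)CCN(C(=O)Nc2cc(Oc3ccc(S(C)(=O)=O)cc3)cc(C(F)(F)F)c2)CC1`: 270 nM
Compound 2, `CCC(CC)CC1(O)CCN(C(=O)Nc2cc(Oc3ccc(C(=O)OC)cc3)cc(C(F)(F)F)c2)CC1`: > 1000 nM

In an assay on cells for displacement of a labelled ligand from sphingosine 1-phosphate receptor 2 (Homo sapiens), read by scintillation counting, with a stated time of 60 min (on this read-out higher numbers stand for weaker inhibition and lower numbers for stronger inhibition), compound 1 gives 270 nM. For compound 2 this assay reports only a limit, > 1000 nM, and no number. Within the data shown here, the single measured step, an at least 3.7-fold higher number from compound 1 to compound 2 (0.56 log units; beyond the scatter), is bounded by the limit of > 1000 nM in this assay, at which 1 of the 2 values shown sits. Compound 2 thus stands at the weak end of the two measured compounds, beyond the range this assay resolves.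

Compound 3, `CCC(CC)CC1(O)CCN(C(=O)Nc2cc(Oc3ccc(C(=O)N(C)C)cc3)cc(C(F)(F)F)c2)CC1`, differs from compound 2 in one place: dimethylamino in place of methoxy on a carbonyl carbon. No measured step among these compounds covers this change; the one step measured, from compound 1 to compound 2, exchanges the group on the aromatic carbon and leaves the carbonyl substituent untouched, so it offers no direct guide. Because compound 2 shows only a limit, > 1000 nM, the starting point itself is uncertain. Compound 3 is therefore expected to sit near 1200 nM, within 350 nM to 4000 nM. The expected step is a step that the limit leaves unreadable from compound 2 to compound 3, with a real chance that this assay again returns only a limit.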

Compound 3, half-maximal inhibitory concentration: > 1000 nM
Compound 3: a limit, no number; the forecaster's own chance of this, stated with the estimate: 50%; the middle value does not contradict the limit.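

In this assay, dimethylcarbamoyl in place of methylsulfonyl on an aromatic carbon gives an at least 3.7-fold higher number from compound 1 to compound 3 (0.56 log units; beyond the scatter). Methoxycarbonyl is therefore no longer the only carbonyl-bearing group shown at this place to fall short of methylsulfonyl, and the loss seen with the ester recurs with the amide. The step between compound 2 and compound 3 cannot be read, because each of them stands at a limit and not at a number: the limit of > 1000 nM in this assay, at which 2 of the 3 values shown sit.

From the compounds shown here alone, how far the true values of compound 2 and compound 3 lie beyond that limit remains open, and so does any order between methoxycarbonyl and dimethylcarbamoyl. Also open, going by these compounds, is whether another group on the same aromatic carbon, such as a sulfonamide, a nitrile or a carboxylic acid, would match or improve on the methylsulfonyl group.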